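The source may hold more compounds than are shown below. What is called first, only, known or untested is meant among the compounds shown, and "the series" means these compounds.

Compound 1, `CCCOC(=O)CCC(=O)N1CCN(CCCOc2cc3c(Nc4ccc(F)c(Cl)c4)ncnc3cc2OC)CC1`, and compound 2, `CCCCCCCOC(=O)CCC(=O)N1CCN(CCCOc2cc3c(Nc4ccc(F)c(Cl)c4)ncnc3cc2OC)CC1`, share one core and differ only in the chain of the ester. In a functional assay on A549 cells (Homo sapiens) for cytotoxicity, read by MTT assay, with a stated time of 24 h, tested at 20 uM (a higher number here means a weaker effect of the compound at the concentration tested, a lower number a stronger effect), compound 1 gives 87%, and compound 2 gives 79.9%. Within the data shown here, of the two numbers, the one for compound 2 is the lower, but the step of a number 7.1 percentage points lower from compound 1 to compound 2 (within the scatter) lies within the scatter, so the two measurements do not separate. Compound 3, `CCCCCCCCCCCCCOC(=O)CCC(=O)N1CCN(CCCOc2cc3c(Nc4ccc(F)c(Cl)c4)ncnc3cc2OC)CC1`, carries the change (hexyl in place of hydrogen on a saturated chain carbon, seven bonds along the chain from an oxygen next to a carbonyl group). Among the measured compounds shown here, the only measured step that bears on this is a number 7.1 percentage points lower from compound 1 to compound 2 (within the scatter), a lengthening of the same chain that left the read-out where it was. A further lengthening is therefore expected to give no step beyond the scatter in this assay, and the expected step is a number 1.9 percentage points lower from compound 2 to compound 3 (within the scatter). For compound 3 the estimate in this assay is 78%, with a range from 65% to 90%.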

Compound 3, a percentage reported as activity, at one concentration (the size of the read-out at that concentration, not a potency): 93.8%
The estimate for compound 3 lay 15.8 percentage points below the measured number; measured number above the stated range.
By their numbers in this assay, from the lowest: compounds 2, 1 and 3 (each within the scatter of the next, the first and the last beyond it).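

In this assay, a change of chain length at this position now separates two compounds: the added hexyl gives a number 13.9 percentage points higher from compound 2 to compound 3 (beyond the scatter), a modest step towards a weaker effect. The added decyl gives a number 6.8 percentage points higher from compound 1 to compound 3 (within the scatter), so compound 1 and compound 3 do not separate, and compound 1 lies within the scatter of both compound 2 and compound 3, which leaves no steady trend with chain length across these three compounds. No measurement at hand accounts for the modest step.

The compounds shown leave open how chains of intermediate length, between those of compound 2 and compound 3, would read at this position. They also leave open whether a carboxylic acid or an amine at the end of the chain would give a different read-out.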